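The compounds below may be only part of what the source reports. "The series", "measured", "known", "first", "only" and "open" are said of these compounds alone.

Of the compounds shown here, two sharing one core have been tested in a functional assay on MDA-N cells (Homo sapiens); on this read-out higher numbers stand for weaker inhibition of growth and lower numbers for stronger inhibition of growth: compound 1 (`COc1cccc(-c2cc(O)c3cc(C)cnc3n2)c1`) and compound 2 (`COc1cccc(-c2cc(O)c3c(C)ccnc3n2)c1`). Compound 1 gives < 10 nM, which is a limit of the assay and not a number. Compound 2 gives < 10 nM, which is likewise a limit and not a number. Compound 2 therefore stands at the limit of < 10 nM in this assay, at which 2 of the 2 values shown sit, with no exact figure to its name. The next compound, compound 3 (`COc1cccc(-c2cc(O)c3cccnc3n2)c1`), differs from compound 2 in one place: hydrogen in place of methyl on an aromatic carbon. In words, hydrogen takes the place of methyl on an aromatic carbon. Going by the values given here, no measured pair shows what such a change does, so any forecast is uncertain. A moderate loss toward weaker inhibition of growth is expected, with an estimated at least 2.5-fold higher number from compound 2 to compound 3 (0.39 log units; beyond the scatter). The expected value for compound 3 is 25 nM, within an estimated range of 6 nM to 150 nM.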

Compound 3, concentration for 50% growth inhibition: < 10 nM
Compound 3 ended at the assay's limit; the forecaster's own chance of this, stated with the estimate: 35%; middle value at least 2.5-fold (0.39 log units) away from the limit.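

Going by these compounds alone, no step from compound 1 or compound 2 to compound 3 can be read in this assay, because all three compounds stand at a limit of the assay: the limit of < 10 nM in this assay, at which 3 of the 3 values shown sit. The compounds shown leave open whether hydrogen in place of methyl on an aromatic carbon changes inhibition of growth at all, and by how much.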